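A Halogen Swap at the Weak End of the Series

The source may hold more compounds than are shown below. What is called first, only, known or untested is meant among the compounds shown, and "the series" means these compounds.

Compound 1 `Cc1ccc(-c2cn(Cc3ccccc3)c3c2CNCC3)cc1`: 35 nM
Compound 2 `Clc1cccc(-c2cn(Cc3ccccc3)c3c2CNCC3)c1`: 10000 nM

Compound 2 gives the highest number of the two in an assay on HEK293 cells for displacement of a labelled ligand from 5-hydroxytryptamine receptor 7 (Rattus norvegicus), with a stated time of 60 min; a lower number here means a stronger inhibitor, a higher number a weaker inhibitor; compound 1 stands nearest, and a 290-fold higher number from compound 1 to compound 2 (2.46 log units; beyond the scatter). Compound 3 `Fc1cccc(-c2cn(Cc3ccccc3)c3c2CNCC3)c1` carries fluoro in place of chloro on an aromatic carbon. For the measured compounds named here, no measured step exchanges one halogen for another, so the single step between compound 1 and compound 2 is only a loose guide; it shows that the number changes greatly with what stands on that ring. Compound 3 is therefore expected to remain weak, giving an expected 3.3-fold lower number from compound 2 to compound 3 (0.52 log units; beyond the scatter). Compound 3 is estimated at 3000 nM, within 500 nM to 10000 nM.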

Compound 3, inhibition constant: 2730 nM
Compound 3: middle estimate off by 1.1-fold (0.04 log units), on the high side; the measured number falls inside the stated range.
By their numbers in this assay, from the lowest: compound 1; then compound 3; then compound 2.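

In this assay, the exchange of one halogen for another on this aromatic carbon has a real but modest effect: a 3.7-fold lower number from compound 2 to compound 3 (0.56 log units; beyond the scatter), so the halogen itself matters here. Even so, the 3-fluorophenyl group recovers only a small part of the gap to the 4-methylphenyl group, with a 78-fold higher number from compound 1 to compound 3 (1.89 log units; beyond the scatter). No evidence at hand accounts for either step.

Still open, going by these compounds, is how a 3-methylphenyl, 3-methoxyphenyl or 4-fluorophenyl group would fare on the shared core. Such groups would help to show whether the large gap follows the halogen or its place on the ring.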